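The compounds below may be only part of what the source reports. "The series", "measured", "known", "first", "only" and "open" are said of these compounds alone.

Compound 1 `O=C(CCc1cn(Cc2ccc3oc(-c4ccccc4)cc(=O)c3c2)nn1)Nc1ccc(Cl)cc1`: 15600 nM
Compound 2 `O=C(CCCCc1cn(Cc2ccc3oc(-c4ccccc4)cc(=O)c3c2)nn1)Nc1ccccc1`: 15600 nM
Compound 3 `Cc1ccc(NC(=O)CCCCc2cn(Cc3ccc4oc(-c5ccccc5)cc(=O)c4c3)nn2)cc1`: 15600 nM

In an assay on isolated protein for inhibition of Amine oxidase [flavin-containing] B (Homo sapiens), read by fluorescence and spectrophotometry (on this read-out lower numbers stand for stronger inhibition and higher numbers for weaker inhibition), compound 3 gives 15600 nM, level with compound 1 at 15600 nM and with compound 2 at 15600 nM; no order among the three can be read from these numbers. Compound 4 `O=C(CCc1cn(Cc2ccc3oc(-c4ccccc4)cc(=O)c3c2)nn1)Nc1ccccc1` differs from compound 3 by a group of 9 heavy atoms (7 carbon, 1 nitrogen, 1 oxygen; one six-membered aromatic ring of carbon only) in place of a group of 12 heavy atoms (10 carbon, 1 nitrogen, 1 oxygen; one six-membered aromatic ring of carbon only), on a saturated chain carbon, two bonds along the chain from an aromatic carbon. Within the data shown here, three measured steps bear on this change: no change at the digits printed from compound 1 to compound 2 (within the scatter), no change at the digits printed from compound 2 to compound 3 (within the scatter) and no change at the digits printed from compound 1 to compound 3 (within the scatter). Every alteration so far of the chain length and of the carbamoyl group has left the read-out unchanged within the scatter, so for compound 4 the step is expected to be no change at the digits printed from compound 3 to compound 4 (within the scatter). Compound 4 is estimated at 15600 nM, with a range from 7000 nM to 35000 nM.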

Compound 4, half-maximal inhibitory concentration: 15600 nM
For compound 4 middle estimate and measured number coincide at the digits printed; low and high end bracket the measured number.
By their numbers in this assay, from the lowest: compounds 1, 2, 3 and 4 (each within the scatter of the next).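

In this assay, the unsubstituted phenylcarbamoyl gives a direct reading of hydrogen in place of chloro, no change at the digits printed from compound 1 to compound 4 (within the scatter), and of phenylcarbamoyl in place of 2-(phenylcarbamoyl)ethyl, no change at the digits printed from compound 2 to compound 4 (within the scatter). The change that removes the methyl and shortens the chain together gives no change at the digits printed from compound 3 to compound 4 (within the scatter), so neither chloro, methyl nor chain length separates these four compounds at this place. No evidence bears on this result. Still open, from the compounds shown here alone, is whether a carboxylic acid or an amine in place of phenylcarbamoyl, or a longer chain, would move the read-out. Changes to the shared core also remain untested here.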